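Compound 4: replacing a dimethylpyrazolyl group with a methylpyridinyl group

The source may report more compounds than this note shows. Statements on the series, on what has been measured and on what is new or still open speak of the compounds shown alone.

compound 1 `Cc1nc(CO)ccc1-c1cnc(NCc2c(F)ccc3c2CCO3)c2cn[nH]c(=O)c12`: 11 mL.min-1.g-1
compound 2 `CN(C)C(=O)c1cc(-c2cnc(NCc3c(F)ccc4c3CCO4)c3cn[nH]c(=O)c23)n(C)n1`: 21 mL.min-1.g-1
compound 3 `Cc1cc(-c2cnc(NCc3c(F)ccc4c3CCO4)c3cn[nH]c(=O)c23)n(C)n1`: 24 mL.min-1.g-1

In an ADME assay on microsomes from liver (Homo sapiens) for metabolic stability, read by LC-MS, using NADPH, with stated times of 5 min and 30 min, tested at 1 uM (a lower number here means slower removal, a higher number faster removal of the compound), compound 3 gives 24 mL.min-1.g-1, level with compound 2 within the scatter and modestly clear of compound 1. The next compound is compound 4 `Cc1ncccc1-c1cnc(NCc2c(F)ccc3c2CCO3)c2cn[nH]c(=O)c12`, which carries 2-methylpyridin-3-yl in place of 1,3-dimethyl-1H-pyrazol-5-yl on an aromatic carbon.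

Among the measured compounds shown here, no measured step makes this exact exchange. The closest is a 2.2-fold higher number from compound 1 to compound 3 (0.34 log units; beyond the scatter), in which the same 1,3-dimethyl-1H-pyrazol-5-yl replaces 6-(hydroxymethyl)-2-methylpyridin-3-yl, a group that carries a hydroxymethyl the entering group lacks. Read in reverse, that step points towards a lower number, but the data do not show how much of it goes with the hydroxymethyl. The step of a 1.1-fold higher number from compound 2 to compound 3 (0.06 log units; within the scatter), methyl in place of dimethylcarbamoyl, stays within the scatter.

The expected step is a 1.5-fold lower number from compound 3 to compound 4 (0.18 log units; within the scatter), smaller than the reverse of the closest step and possibly within the scatter. The estimate for compound 4 is 16 mL.min-1.g-1, with an expected range from 8 mL.min-1.g-1 to 30 mL.min-1.g-1.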

Compound 4, intrinsic clearance in microsomes in the Homo sapiens assay: 41 mL.min-1.g-1
Compound 4: middle estimate off by 2.6-fold (0.41 log units), on the low side; the whole stated range lies below it.
By their numbers in the Homo sapiens assay, from the lowest: compounds 1, 2, 3 and 4 (each within the scatter of the next, the first and the last beyond it).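

In the Homo sapiens assay the ring exchange at this position shows a 1.7-fold higher number from compound 3 to compound 4 (0.23 log units; within the scatter) and a 2.0-fold higher number from compound 2 to compound 4 (0.29 log units; within the scatter), so the 2-methylpyridin-3-yl group by itself does not bring the low number of compound 1. Among the compounds shown here, the one clear single change in the Homo sapiens assay is a 3.7-fold higher number from compound 1 to compound 4 (0.57 log units; beyond the scatter), which links that low number to the hydroxymethyl on the pyridine ring rather than to the ring exchange. In a physicochemical assay for lipophilicity, using the shake flask method, in phosphate buffer, measured as octanol-water partition, with a stated time of 30 min, at pH 7.4 (on this read-out lower numbers stand for lower lipophilicity and higher numbers for higher lipophilicity), the ring exchange shows no change at the digits printed from compound 3 to compound 4 (within the scatter). In the physicochemical assay compound 3 gives 3 and compound 4 gives 3.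

Nothing given here explains why the hydroxymethyl goes with the lower number. As far as these compounds go, it remains open whether a methoxymethyl, an aminomethyl or a carboxylic acid in its place would go with a similarly low number, and whether a hydroxymethyl on the 1,3-dimethyl-1H-pyrazol-5-yl ring would do the same.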